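The source may hold more compounds than are shown below. What is called first, only, known or untested is meant among the compounds shown, and "the series" means these compounds.

Working notes on the series. In a functional assay on HeLa cells (Homo sapiens) for antiproliferative activity, read by WST assay, with a stated time of 24 h (a higher number here means a weaker inhibitor, a lower number a stronger inhibitor), compound 2 `C=C[C@]1(C)CC[C@@H](C(=C)Cn2ccnc2)C[C@H]1C(=C)C` gives 15700 nM, the middle of three values, with compound 3 `C=C[C@]1(C)CC[C@@H](C(=C)CNC2CCCCCCC2)C[C@H]1C(=C)C` lower at 5900 nM and compound 1 `C=C[C@]1(C)CC[C@@H](C(=C)COCCOC)C[C@H]1C(=C)C` far higher at 238000 nM. Compound 4 `C=C[C@]1(C)CC[C@@H](C(=C)CN(CC)CC)C[C@H]1C(=C)C` differs from compound 2 as follows: diethylamino in place of 1H-imidazol-1-yl on a saturated chain carbon bound to a double-bonded chain carbon. In words, this is diethylamino in place of 1H-imidazol-1-yl on a saturated chain carbon bound to a double-bonded chain carbon. Among the compounds with values here, the one measured step at this place, a 15-fold lower number from compound 1 to compound 2 (1.18 log units; beyond the scatter), is large, but it does not involve diethylamino and offers only limited guidance. Compound 3, with an amine on the same carbon, gives 5900 nM, so only a small move towards a lower number is expected in this assay, possibly none beyond the scatter. The expected change is a 1.4-fold lower number from compound 2 to compound 4 (0.15 log units; within the scatter). For compound 4 the estimate is 11000 nM, with an expected range of 4000 nM to 30000 nM.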

Compound 4, half-maximal inhibitory concentration: 14400 nM
The estimate for compound 4 lay 1.3-fold (0.12 log units) below the measured number, within the range that was stated.
By their numbers in this assay, from the lowest: compound 3; then compounds 4 and 2 (each within the scatter of the next); then compound 1.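

In this assay diethylamino in place of 1H-imidazol-1-yl gives a 1.1-fold lower number from compound 2 to compound 4 (0.04 log units; within the scatter) and so the five-membered aromatic ring is not required for this level of value on a saturated chain carbon bound to a double-bonded chain carbon. Diethylamino in place of 2-methoxyethoxy gives a 17-fold lower number from compound 1 to compound 4 (1.22 log units; beyond the scatter) and thus a second large step away from the ether-bearing compound 1, alongside a 15-fold lower number from compound 1 to compound 2 (1.18 log units; beyond the scatter) at the same place. Nothing available bears on the reason for this result.

As far as these compounds go, it remains open whether a morpholine or a carboxylic acid on this carbon would read like the nitrogen groups or like 2-methoxyethoxy.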